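Amine variation at the aromatic carbon, four analogues

The source may hold more compounds than are shown below. What is called first, only, known or untested is meant among the compounds shown, and "the series" means these compounds.

Compound 1 `CCCCN(C)c1cc(C(F)(F)F)ccc1CNC(=O)C(C)c1ccc(NS(C)(=O)=O)c(F)c1`: 1.2 nM
Compound 2 `CCCN(CCC)c1cc(C(F)(F)F)ccc1CNC(=O)C(C)c1ccc(NS(C)(=O)=O)c(F)c1`: 0.3 nM
Compound 3 `CCC1CCN(c2cc(C(F)(F)F)ccc2CNC(=O)C(C)c2ccc(NS(C)(=O)=O)c(F)c2)CC1`: 0.7 nM

In an assay on CHO cells for antagonist activity at transient receptor potential cation channel subfamily V member 1 (Homo sapiens), read by FLIPR (on this read-out higher numbers stand for weaker inhibition and lower numbers for stronger inhibition), compound 3 stands second highest of the three numbers. Its nearest neighbour is compound 1 (a 1.7-fold lower number from compound 1 to compound 3 (0.23 log units; within the scatter)); its furthest is compound 2 (a 2.3-fold higher number from compound 2 to compound 3 (0.37 log units; beyond the scatter)). Compound 4 `CC(C(=O)NCc1ccc(C(F)(F)F)cc1N1CCC(c2ccc(F)cc2)CC1)c1ccc(NS(C)(=O)=O)c(F)c1` differs from compound 3 by 4-fluorophenyl in place of ethyl on a saturated ring carbon. Within the data shown here, no measured pair alters the group on that saturated ring carbon; the steps in hand, a 4.0-fold lower number from compound 1 to compound 2 (0.60 log units; beyond the scatter) and a 2.3-fold higher number from compound 2 to compound 3 (0.37 log units; beyond the scatter), concern only the amine as a whole and were modest. The step of a 1.4-fold higher number from compound 3 to compound 4 (0.15 log units; within the scatter) is therefore expected to be small, quite possibly none beyond the scatter, with no firm direction. Compound 4 is estimated in this assay at 1 nM, between 0.3 nM and 3.5 nM.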

Compound 4, inhibition constant: 0.9 nM
Compound 4: middle estimate off by 1.1-fold (0.05 log units), on the high side; the measured number falls inside the stated range.
By their numbers in this assay, from the lowest: compound 2; then compounds 3, 4 and 1 (each within the scatter of the next).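

On the saturated ring carbon, three ring bonds from the ring nitrogen, 4-fluorophenyl in place of ethyl gives a 1.3-fold higher number from compound 3 to compound 4 (0.11 log units; within the scatter) in this assay. Among these compounds, a six-membered aromatic ring can therefore stand at this position with no change beyond the scatter, whereas the earlier steps concerned only the amine as a whole. No evidence is at hand on what lies behind this result.

From the compounds shown here alone, it remains open whether a carboxylic acid or an amine on that carbon would also stay within the scatter. Also open, going by these compounds, is whether phenyl without the fluorine would match compound 4.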